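A few compounds are considered here, and "the series" means these few. Any claim that something is new, unique, unknown or untested is made for them only; others in the source may bear on it.

Measured so far in an assay on cells for agonist activity at probable G-protein coupled receptor 34 (Mus musculus), with a stated time of 1 h; on this read-out lower numbers stand for smaller maximal responses and higher numbers for larger maximal responses:

compound 1, `N[C@@H](COP(=O)(O)OCCCOC(=O)CCc1ccccc1OCCCCOc1ccccc1)C(=O)O`: 6.1%
compound 2, `N[C@@H](COP(=O)(O)OCCCOC(=O)CCc1ccccc1OCCCCCCOc1ccccc1)C(=O)O`: 20.7%
compound 3, `N[C@@H](COP(=O)(O)OCCCOC(=O)CCc1ccccc1OCc1cccc(Oc2ccccc2Cl)c1)C(=O)O`: 19.8%

Compound 3 stands second highest of the three numbers. Its nearest neighbour is compound 2, whose value lies within the scatter of that of compound 3, so the two are not told apart; compound 1 lies beyond the scatter below compound 3.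

The next compound to be measured is compound 4, `CC(C)(C)c1ccc(Oc2cccc(COc3ccccc3CCC(=O)OCCCOP(=O)(O)OC[C@H](N)C(=O)O)c2)cc1`. It differs from compound 3 in one place: 4-(tert-butyl)phenyl in place of 2-chlorophenyl on an oxygen on an aromatic ring.

Going by the values given here, only one step has been measured, a number 14.6 percentage points higher from compound 1 to compound 2 (beyond the scatter). That step concerns a different place, the chain linking the two aryl ethers, and the aryl group itself was unchanged there; it therefore gives no direct guide to the exchange of the aryl group in compound 4. Among the compounds with values here, no measured pair varies the substituent on the terminal aromatic ring. In this assay the step from compound 3 to compound 4 is thus expected to be small, with no direction supported by the data; the estimate is a number 2.2 percentage points higher from compound 3 to compound 4 (within the scatter).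

Compound 4 is accordingly estimated at 22% in this assay, with a range from 8% to 40%.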

Compound 4, largest response reached (Emax), in percent of the reference or control that the assay uses: 16.9%
The estimate for compound 4 lay 5.1 percentage points above the measured number, and the stated range covers the measured number.
By their numbers in this assay, from the lowest: compound 1; then compounds 4, 3 and 2 (each within the scatter of the next).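

In this assay, going by these compounds alone, the only measured pair that varies the aryl group on this oxygen gives a number 2.9 percentage points lower from compound 3 to compound 4 (within the scatter), so compound 3 and compound 4 are not told apart. Replacing 2-chlorophenyl with 4-(tert-butyl)phenyl, which takes the group from 7 to 10 heavy atoms and exchanges the chlorine for carbon only, leaves the maximal response unresolved at this position in this one pair. No supporting data bear on this result, and the step offers no basis for an explanation.

The exchange alters both the substituent and its place on the ring, so the pair cannot separate the two, and a plain phenyl or a ring carrying an amine or a carboxylic acid would be needed to show whether this position responds to the substituent at all. Also open, going by these compounds, is whether any group here can lift the response in this assay clearly beyond the level shared by compound 3 and compound 4, since two members of one pair within the scatter define no trend.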